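A few compounds are considered here, and "the series" means these few. Any claim that something is new, unique, unknown or untested is made for them only; others in the source may bear on it.

Among the compounds with values here, compound 2 `CC(C)[C@H](NC(=O)COc1cccc2ccccc12)C(=O)N[C@@H](CC(=O)O)C(=O)CSc1ncc[nH]1` is one of two compounds measured in a functional assay on Jurkat cells (Homo sapiens) for inhibition; a lower number here means a stronger inhibitor, a higher number a weaker inhibitor. In this assay compound 2 gives > 200000 nM, which is a limit of the assay rather than a number. Compound 1 `CC(C)c1cc(OCC(=O)[C@H](CC(=O)O)NC(=O)[C@@H](NC(=O)COc2cccc3ccccc23)C(C)C)no1` likewise gives > 200000 nM in this assay, again a limit. The step that the two limits leave unreadable from compound 1 to compound 2 therefore cannot be read. Compound 3 `CC(C)[C@H](NC(=O)COc1cccc2ccccc12)C(=O)N[C@@H](CC(=O)O)C(=O)CSc1nc(-c2ccccc2)no1` differs from compound 2 by 3-phenyl-1,2,4-oxadiazol-5-yl in place of 1H-imidazol-2-yl on a sulfur. Within the data shown here, no measured step touches this change, and the measured values fall at the limit of > 200000 nM in this assay, at which 2 of the 2 values shown sit, so neither size nor direction can be drawn from them. Compound 3 is expected to stay near that limit, an estimated 150000 nM with a range from 30000 nM to 300000 nM, a step of an at least 1.3-fold lower number from compound 2 to compound 3 (0.12 log units; that floor lies within the scatter).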

Compound 3, half-maximal inhibitory concentration: 102000 nM
Compound 3: middle estimate off by 1.5-fold (0.17 log units), on the high side; measured number inside the range.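

With the (3-phenyl-1,2,4-oxadiazol-5-yl)sulfanyl group, compound 3 is the only one of the three to give a number rather than a limit in this assay: the limit of > 200000 nM in this assay, at which 2 of the 3 values shown sit. The change amounts to an at least 1.9-fold lower number from compound 2 to compound 3 (0.29 log units; that floor lies within the scatter) and to an at least 1.9-fold lower number from compound 1 to compound 3 (0.29 log units; that floor lies within the scatter), so both steps point to a lower number, but neither floor lies beyond the scatter. The step between the two limits cannot be read. The compounds shown leave open whether the phenyl ring or the 1,2,4-oxadiazole ring accounts for this number, and how an amine or a carboxylic acid on that phenyl ring would read.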